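The source may hold more compounds than are shown below. What is called first, only, known or untested is meant among the compounds shown, and "the series" means these compounds.

In an ADME assay on Vero cells (Chlorocebus sabaeus) for cytotoxicity, read by MTT assay, with a stated time of 96 h (on this read-out lower numbers stand for higher toxicity in this test and higher numbers for lower toxicity in this test), compound 1 (`CC(=O)c1ccc2[nH]c(-c3ccc(C(F)(F)F)cc3)nc2c1`) gives > 100000 nM, which is a limit of the assay and not a number. Within the data shown here, the only close relative, compound 2 (`C/C(=N\O)c1ccc2[nH]c(-c3ccc(C(F)(F)F)cc3)nc2c1`), has the entry "not determined" (no result reported), so no measured pair of compounds shows how large a step in this assay can be. The next compound to be tested is compound 3 (`CC(=O)c1ccc2c(c1)nc(-c1ccc(C(F)(F)F)cc1)n2C1CCCCC1`), which has cyclohexyl in place of hydrogen on an aromatic nitrogen. Among the measured compounds shown here, with no measured step as a guide, this is a cautious expectation of a modest move toward lower numbers, and the result may again be reported only as a limit. The expected size of the change is an at least 1.4-fold lower number from compound 1 to compound 3 (0.15 log units; that floor lies within the scatter). For compound 3 the estimated value is 70000 nM, with an expected range from 20000 nM to 100000 nM.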

Compound 3, half-maximal cytotoxic concentration: 35000 nM
Compound 3: the middle estimate sits 2.0-fold (0.30 log units) above what was measured, within the range that was stated.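

Among these compounds, putting cyclohexyl in place of hydrogen on the aromatic nitrogen gives the first step that can be read in this assay, namely an at least 2.8-fold lower number from compound 1 to compound 3 (0.45 log units; beyond the scatter), so a change at this nitrogen does register in the read-out, moving toward higher toxicity in this test. Compound 3 is also the only compound shown with a single number rather than a limit, which gives later changes at this position a firm value for comparison. The step can be stated only as a minimum because one of its two ends is a limit and not a number: the limit of > 100000 nM in this assay, at which 1 of the 3 values shown sits.

With one group at this nitrogen, the data cannot separate the effect of cyclohexyl itself from that of any other replacement for hydrogen. A methyl group, a longer chain or a chain ending in an amine could move the value by more, by less or not at all.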